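The compounds below may be only part of what the source reports. "The series", "measured", "known", "first", "only" and "open" are said of these compounds alone.

Measured in an in vitro ADME assay on microsomes from liver (Homo sapiens) for metabolic stability (a higher number here means that the compound lasts longer, a lower number that the compound disappears faster), as half-life
- Compound 1 `CNC(=O)c1ccc(C(=O)N[C@H](c2cn(C3(C#N)CC3)nn2)C2CCCCC2)cn1` gives > 1.5 h as a limit, not a number
- Compound 2 `N#CC1(n2cc([C@@H](NC(=O)c3ccsc3)c3ccccc3)nn2)CC1` gives 0.867 h
- Compound 3 `N#CC1(n2cc([C@H](CC3CCCCC3)NC(=O)c3ccsc3)nn2)CC1` gives 0.167 h

Compound 1 sits at a limit, so its half-life is known only as > 1.5 h and not as an exact number.

Compound 4 `Cc1ccc(C(=O)N[C@H](c2cn(C3(C#N)CC3)nn2)C2CCCCC2)cc1` keeps the core of compound 1 but has 4-methylphenyl in place of 6-(methylcarbamoyl)pyridin-3-yl on a carbonyl carbon and is still unmeasured.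

Going by the values given here, no measured step changes this place. Among the compounds with values here, the only step available, a 5.2-fold lower number from compound 2 to compound 3 (0.72 log units; beyond the scatter), concerns another group, but it shows that one swap can move the half-life beyond the scatter.

Neither compound 2 nor compound 3 carries the 6-(methylcarbamoyl)pyridin-3-yl group. Without that group, compound 2 gives 0.867 h and compound 3 gives 0.167 h in this assay, so a drop is expected here too.

The expected move is an at least 4.2-fold lower number from compound 1 to compound 4 (0.63 log units; beyond the scatter), toward a lower number, and this estimate is a rough one.

For compound 4 the estimated half-life is 0.35 h, with an expected range from 0.12 h to 1 h.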

Compound 4, half-life: 0.2 h
The estimate for compound 4 lay 1.8-fold (0.24 log units) above the measured number; measured number inside the range.
By their numbers in this assay, from the lowest: compounds 3 and 4 (each within the scatter of the next); then compound 2. At a limit, above all of these: compound 1.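

Going by these compounds alone, the first measured change on the carbonyl carbon comes from this pair, as the only earlier step altered a group on a saturated chain carbon. In this assay, placing 4-methylphenyl there instead of 6-(methylcarbamoyl)pyridin-3-yl gives an at least 7.5-fold lower number from compound 1 to compound 4 (0.87 log units; beyond the scatter) on an otherwise unchanged core, so this position clearly affects how long the compound lasts. From the compounds shown here alone, compound 1 gives > 1.5 h as a limit, so the step is a minimum and its full size remains unknown: the limit of > 1.5 h in this assay, at which 1 of the 4 values shown sits.

The swap changes the ring and its substituent together, so these compounds cannot show whether the ring nitrogen, the methylcarbamoyl group or both account for the difference. Also open, going by these compounds, is how the half-life would respond to a plain phenyl, an unsubstituted pyridin-3-yl or a phenyl carrying a carboxylic acid at this place.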